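From tert-butyl to butyl on the aromatic ring

The compounds below may be only part of what the source reports. "The series", "measured", "known", "first", "only" and "open" are said of these compounds alone.

In an ADME assay on THP-1 cells (Homo sapiens) for cytotoxicity, read by resazurin assay, with a stated time of 72 h (on this read-out lower numbers stand for higher toxicity in this test and higher numbers for lower toxicity in this test), compound 3 (`CC(C)(C)c1ccc(C(=O)/C=C/c2ccc([N+](=O)[O-])s2)cc1`) gives 8400 nM as the lowest of the two numbers obtained so far. Compound 2 (`O=C(/C=C/c1ccc([N+](=O)[O-])o1)c1ccc(-c2ccccc2)cc1`) gives 50400 nM on the same read-out, a higher number by a margin beyond the usual scatter. Compound 1 (`CC(C)(C)c1ccc(C(=O)/C=C/c2ccc([N+](=O)[O-])o2)cc1`) reports > 50000 nM in this assay and that value is a limit of the assay, not a number.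

Compound 4 (`CCCCc1ccc(C(=O)/C=C/c2ccc([N+](=O)[O-])s2)cc1`) keeps the core of compound 3 and carries butyl in place of tert-butyl on an aromatic carbon, para to a large group (butyl in place of tert-butyl on an aromatic carbon). The two have the same atoms, joined differently. Among the measured compounds shown here, only one measured step touches that place, phenyl in place of tert-butyl on an aromatic carbon, and it sits on the core of compound 1 rather than that of compound 3. The expectation therefore rests on compound 3 at 8400 nM because a step that the limit leaves unreadable from compound 1 to compound 2 offers no size to carry over. No step beyond the scatter is expected in this assay and the estimated change is a 1.1-fold lower number from compound 3 to compound 4 (0.05 log units; within the scatter) here. The estimate for compound 4 is 7500 nM with an expected range of 2800 nM to 20000 nM on this read-out.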

Compound 4, half-maximal cytotoxic concentration: 17100 nM
Estimate against measurement, compound 4: 2.3-fold (0.36 log units) below; the range from low to high includes it.
By their numbers in this assay, from the lowest: compound 3; then compound 4; then compound 2.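

In this assay, among the compounds shown here, moving from tert-butyl to butyl on an aromatic carbon, para to a large group, gives a 2.0-fold higher number from compound 3 to compound 4 (0.31 log units; beyond the scatter), which is the first step at this position whose size can be read. The earlier step at this place, phenyl in place of tert-butyl from compound 1 to compound 2, cannot be read, because compound 1 reports only a limit: the limit of > 50000 nM in this assay, at which 1 of the 4 values shown sits. The two chains have the same atoms, joined differently, and neither has a ring, so this rearrangement alone, with no atom gained or lost, moves the number beyond the scatter towards lower toxicity in this test, but nothing measured here bears on why it does so.

The compounds shown leave open whether a longer chain, an amine or a carboxylic acid at this place would carry the number further in the same direction or reverse it. They also leave open how the same change from tert-butyl to butyl would read on the core of compound 1, and how phenyl would read on the core of compound 3.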